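Cytotoxicity notes: carboxy for nitro on the ester series

This account rests on a few compounds, and the source may have more. Where it says the series, first, only, none or still open, it means among the compounds named here.

Measured so far in a toxicity assay on HepG2 2.2.15 cells (Homo sapiens) for cytotoxicity, read by CCK-8 assay, with a stated time of 8 days; on this read-out higher numbers stand for lower toxicity in this test and lower numbers for higher toxicity in this test:
Compound 1, `CC(C)Cc1nn(-c2cccc(F)c2)cc1C(=O)NCC1CCN(C(=O)OC(C)(C)C)CC1`, gives > 100000 nM, a limit of the assay rather than a number.
Compound 2, `CCOC(=O)c1cn(-c2ccc([N+](=O)[O-])cc2)nc1CC(C)C`, gives > 100000 nM, again only a limit.
Compound 3, `CC(C)Cc1nn(-c2nccs2)cc1C(=O)NCc1ccc(O)cc1`, gives > 100000 nM, also a limit.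

Compound 2 therefore stands where every value shown stands: at the limit of > 100000 nM in this assay, at which 3 of the 3 values shown sit. No number separates it from compound 1 or compound 3, and no ordering among the three can be read from these limits.

The next compound, compound 4, `CCOC(=O)c1cn(-c2ccc(C(=O)O)cc2)nc1CC(C)C`, differs from compound 2 by carboxy in place of nitro on an aromatic carbon. Going by the values given here, no measured pair carries this change, so no step size is known for it. Given that compound 2 itself sits only at a limit, the expectation is a step of no size beyond the scatter, in no particular direction, from compound 2 to compound 4, written as a number no higher from compound 2 to compound 4 (the limit leaves the size open). Compound 4 is thus estimated at 100000 nM, with a range from 50000 nM to 300000 nM, most likely reported as a limit again.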

Compound 4, half-maximal cytotoxic concentration: > 100000 nM
Compound 4 was reported as a limit; the forecaster's own chance of this, stated with the estimate: 85%; the middle value lies on the limit itself.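

No step can be read from compound 2 to compound 4 in this assay, as both stand only at a limit: the limit of > 100000 nM in this assay, at which 4 of the 4 values shown sit.

The compounds shown leave open whether carboxy in place of nitro on an aromatic carbon changes the read-out in this assay at all.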